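The compounds below may be only part of what the source reports. "The series", "measured", "known", "first", "only" and "open" are said of these compounds alone.

Measured so far in a functional assay on NCI-H460 cells (Homo sapiens) for inhibition, read by MTT assay, with a stated time of 24 h, tested at 10 ug/mL; on this read-out lower numbers stand for less inhibition of growth and higher numbers for more inhibition of growth at the one concentration tested:
compound 1, `O=C(CCCCC1CCSS1)Nc1ccc(Cl)cn1`, gives 33.7%
compound 2, `O=C(CCCCC1CCSS1)Nc1cccc2ccccc12`, gives "not active" (no number reported)
compound 3, `O=C(CCCCC(S)CCS)Nc1ccc(Cl)cn1`, gives 27.4%

Compound 1 and compound 3 share one core and differ in a single place: a group of 5 heavy atoms (3 carbon, 2 sulfur; no ring) in place of a group of 5 heavy atoms (3 carbon, 2 sulfur; one five-membered non-aromatic ring with 2 hetero atoms), on a saturated chain carbon, four bonds along the chain from a carbonyl carbon. The step from the ring form to the open form is a number 6.3 percentage points lower from compound 1 to compound 3 (within the scatter), so the two results cannot be told apart by this assay. Compound 2 carries the other core; the difference between the core of compound 1 and the core of compound 2 is not broken down here. In this assay compound 2 is reported only as "not active" (no number reported), without a number.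

Compound 4, `O=C(CCCCC(S)CCS)Nc1cccc2ccccc12`, is not yet measured. It stands to compound 2 exactly as compound 3 stands to compound 1: a group of 5 heavy atoms (3 carbon, 2 sulfur; no ring) in place of a group of 5 heavy atoms (3 carbon, 2 sulfur; one five-membered non-aromatic ring with 2 hetero atoms), on a saturated chain carbon, four bonds along the chain from a carbonyl carbon. The place of the change is the same word for word in both pairs, so this is the same change made on a second core. Among the compounds shown it occurs twice in all.

Going by the values given here, the one measured instance of the change, a number 6.3 percentage points lower from compound 1 to compound 3 (within the scatter), lies within the scatter, and compound 2 on the naphthyl core gives "not active" (no number reported). Compound 4 is therefore expected to show little growth inhibition, about 10% in this assay, with a plausible range from 0% to 25%. It is also quite possible that compound 4, like compound 2, is reported without a number.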

Compound 4, percent growth inhibition at one concentration: "not active" (no number reported)
Compound 4: no number reported, so the estimate cannot be set against anything.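

In this assay compound 2 gives "not active" (no number reported) and compound 4 gives "not active" (no number reported), so no step can be read between compound 2 and compound 4. The compounds shown leave open whether 1,3-disulfanylpropyl in place of the ring changes growth inhibition on the core of compound 2 at all. No measurement shown here offers an explanation for this result.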